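The source may report more compounds than this note shows. Statements on the series, on what has been measured and on what is new or still open speak of the compounds shown alone.

In a functional assay on ASPC1 cells (Homo sapiens) for antiproliferative activity, read by MTT assay, with a stated time of 72 h (on this read-out higher numbers stand for weaker inhibition and lower numbers for stronger inhibition), compound 1 (`C=CC(=O)Nc1cc(Nc2nccc(NC(=O)c3cccc(OC)c3)n2)c(OC)cc1N1CCN(C)CC1`) reads > 10000 nM, which is a limit of the assay and not a number. Among the compounds with values here, compound 2 (`C=CC(=O)Nc1cc(Nc2nccc(NC(=O)c3cccc(OC)c3)n2)c(OC)cc1N(C)CCN(C)C`) gives 3400 nM, the only actual number so far.

Compound 3 (`C=CC(=O)Nc1cc(Nc2nccc(NC(=O)c3ccc(C(F)(F)F)cc3)n2)c(OC)cc1N(C)CCN(C)C`) keeps the (2-(dimethylamino)ethyl)(methyl)amino group of compound 2 and changes the other end of the molecule: 4-(trifluoromethyl)phenyl in place of 3-methoxyphenyl on a carbonyl carbon. This places 4-(trifluoromethyl)phenyl in place of 3-methoxyphenyl on a carbonyl carbon.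

Within the data shown here, the sole measured step, an at least 2.9-fold lower number from compound 1 to compound 2 (0.46 log units; beyond the scatter), concerns the amine group on the aromatic carbon and not this carbonyl position. It therefore gives no direct guide to the size or direction of the new change. Among the measured compounds shown here, with no measured step at this place, no shift beyond the scatter is expected in this assay, and the uncertainty is wide. The expected step is a 1.1-fold lower number from compound 2 to compound 3 (0.05 log units; within the scatter). The estimate for compound 3 is 3000 nM, with an expected range of 700 nM to 10000 nM.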

Compound 3, half-maximal inhibitory concentration: 8030 nM
The estimate for compound 3 lay 2.7-fold (0.43 log units) below the measured number; low and high end bracket the measured number.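

In this assay the carbonyl position responds to substitution, with a 2.4-fold higher number from compound 2 to compound 3 (0.37 log units; beyond the scatter) for 4-(trifluoromethyl)phenyl in place of 3-methoxyphenyl. This is the first measured step at this place, and it runs toward weaker inhibition, so 3-methoxyphenyl is the better of the two groups shown on the carbonyl carbon while the (2-(dimethylamino)ethyl)(methyl)amino group stays fixed. Compound 1 remains at a limit of the assay and not a number: the limit of > 10000 nM in this assay, at which 1 of the 3 values shown sits.

The change alters both the substituent and its printed ring number, so the two contributions cannot be separated; a 4-methoxyphenyl or a plain phenyl on the carbonyl carbon would address this. Going by these compounds, how 4-(trifluoromethyl)phenyl behaves with 4-methylpiperazin-1-yl on the aromatic carbon also remains open.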